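This account rests on a few compounds, and the source may have more. Where it says the series, first, only, none or still open, it means among the compounds named here.

Measured in an ADME assay on HOS cells (Homo sapiens) for cytotoxicity, read by luminescence and ATP content, with a stated time of 48 h; a lower number here means that less compound is tolerated, a higher number that more compound is tolerated:
- Compound 1 `Nc1c(C(=O)NCc2ccc(F)cc2F)c(=O)n(O)c2ncc(CCCCc3ccccc3)cc12`: 13000 nM
- Compound 2 `CN(C)CCCc1cnc2c(c1)c(N)c(C(=O)NCc1ccc(F)cc1F)c(=O)n2O`: 5000 nM
- Compound 3 `CN(C)C(=O)/C=C/c1cnc2c(c1)c(N)c(C(=O)NCc1ccc(F)cc1F)c(=O)n2O`: > 250000 nM (a limit, not a number)

Compound 3 is the best tolerated of the three, and its result is the limit of > 250000 nM in this assay, at which 1 of the 3 values shown sits. Compound 4 `Nc1c(C(=O)NCc2ccc(F)cc2F)c(=O)n(O)c2ncc(CCC(=O)NCCO)cc12` has not yet been measured. It differs from compound 3 in one place: 2-((2-hydroxyethyl)carbamoyl)ethyl in place of 2-(dimethylcarbamoyl)ethenyl on an aromatic carbon. It keeps a carbamoyl group, as compound 3 does, but its chain is saturated, like those of compound 1 and compound 2.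

The evidence is indirect. The two large steps, an at least 19-fold higher number from compound 1 to compound 3 (1.28 log units; beyond the scatter) and an at least 50-fold higher number from compound 2 to compound 3 (1.69 log units; beyond the scatter), separate compound 3 from those saturated chains, but neither of those chains carries a carbamoyl group. The third step, a 2.6-fold lower number from compound 1 to compound 2 (0.41 log units; beyond the scatter), is only modest. In this assay, a small downward change or none is therefore expected, and the result may again be only a limit. The expected step is an at least 1.3-fold lower number from compound 3 to compound 4 (0.14 log units; that floor lies within the scatter). For compound 4 the estimate is 180000 nM, with an expected range of 50000 nM to 250000 nM.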

Compound 4, half-maximal cytotoxic concentration: > 250000 nM
Compound 4: no number, only a limit; the forecaster's own chance of this, stated with the estimate: 55%; middle value at least 1.3-fold (0.14 log units) from the limit.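

In this assay, the saturated chain of compound 4 does not bring the low numbers of the other saturated chains, giving an at least 50-fold higher number from compound 2 to compound 4 (1.69 log units; beyond the scatter) and an at least 19-fold higher number from compound 1 to compound 4 (1.28 log units; beyond the scatter). A result at the limit at this position therefore does not depend on the double bond of compound 3, though compound 1 and compound 2 show that a saturated chain alone, without a carbamoyl group, does not reach it. The step between compound 3 and compound 4 cannot be read, because both results are limits rather than numbers: the limit of > 250000 nM in this assay, at which 2 of the 4 values shown sit.

Going by these compounds, what remains open is whether the carbamoyl group or the hydroxyethyl end matters more. A saturated chain ending in a carboxylic acid or a plain dimethylcarbamoyl group would help separate the two, and neither is among these compounds.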